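A few compounds are considered here, and "the series" means these few. Any claim that something is new, unique, unknown or untested is made for them only; others in the source may bear on it.

In a functional assay on KBVIN cells (Homo sapiens) for antiproliferative activity, read by sulforhodamine B assay, with a stated time of 3 days (a higher number here means that more compound is needed for the effect, a lower number that less compound is needed), compound 1 (`CCC1=C(O)c2c(oc(-c3ccc(COC)cc3)cc2=O)C(CC)(CC)C1=O`) gives 3.4 uM and compound 2 (`CCC1=C(O)c2c(oc(-c3ccc(OC)cc3C)cc2=O)C(CC)(CC)C1=O`) gives 2.62 uM. Compound 3 (`CCC1=C(O)c2c(oc(-c3cc(C)c(O)c(C)c3)cc2=O)C(CC)(CC)C1=O`) has the highest number of the three at 8.9 uM. The next structure is compound 4 (`CCC1=C(O)c2c(oc(-c3cc(C)ccc3C)cc2=O)C(CC)(CC)C1=O`), with 2,5-dimethylphenyl in place of 4-hydroxy-3,5-dimethylphenyl on an aromatic carbon of the shared core: 2,5-dimethylphenyl in place of 4-hydroxy-3,5-dimethylphenyl on an aromatic carbon.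

The closest evidence comes from the two steps that introduce the departing group: a 2.6-fold higher number from compound 1 to compound 3 (0.42 log units; beyond the scatter) and a 3.4-fold higher number from compound 2 to compound 3 (0.53 log units; beyond the scatter). Both are modest and beyond the scatter. By contrast, a 1.3-fold lower number from compound 1 to compound 2 (0.11 log units; within the scatter) stays within the scatter, so the two measured compounds without that group give similar numbers. Among the measured compounds shown here, no measured compound carries 2,5-dimethylphenyl, so this reading is only a guide. Read in reverse, the two modest steps point to a modest fall in this assay on losing the group. The expected change is a 2.8-fold lower number from compound 3 to compound 4 (0.44 log units; beyond the scatter). The estimate for compound 4 is 3.2 uM, with an expected range of 1.3 uM to 7.5 uM.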

Compound 4, concentration for half-maximal effect: 3.41 uM
Estimate against measurement, compound 4: 1.1-fold (0.03 log units) below, and the stated range covers the measured number.
By their numbers in this assay, from the lowest: compounds 2, 1 and 4 (each within the scatter of the next); then compound 3.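

In this assay, compound 4 gives a step from the hydroxylated compound that is beyond the scatter (a 2.6-fold lower number from compound 3 to compound 4 (0.42 log units; beyond the scatter)), while it cannot be told apart from the two aryl compounds with an ether oxygen (a 1.3-fold higher number from compound 2 to compound 4 (0.11 log units; within the scatter) and a 1.0-fold higher number from compound 1 to compound 4 (0.00 log units; within the scatter)). At this position next to the ring oxygen, an aryl group of carbon only therefore matches 4-methoxy-2-methylphenyl and 4-(methoxymethyl)phenyl, and among the four compounds, only compound 3 with 4-hydroxy-3,5-dimethylphenyl stands apart. Nothing at hand gives a reason for this difference.

Compound 4 differs from compound 3 in both the hydroxyl and the placement of the methyl groups, and the two changes cannot be separated here. On these data alone, how an amine, a carboxylic acid or a longer alkyl chain on this aryl ring would read remains open.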